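A few compounds are considered here, and "the series" means these few. Any claim that something is new, unique, unknown or untested is made for them only; others in the source may bear on it.

Working notes on the series.

Within the data shown here, compound 1 `N/C(CC(O)c1cccc2ccccc12)=N\N=C\c1ccc(Cl)c(Cl)c1` is the only member with a number in an ADME assay on L6 cells (Rattus norvegicus) for cytotoxicity, read by resazurin assay, with a stated time of 72 h; on this read-out higher numbers stand for weaker inhibition and lower numbers for stronger inhibition: compound 1 gives 16000 nM. Among the measured compounds shown here, it therefore stands alone as the single point of reference; no other compound of the series carries a value against which it can be ranked. Compound 2 `N/C(CC(O)c1ccc2ccccc2c1)=N\N=C\c1ccco1` belongs to the same series, but in this assay compound 2 returned "not determined" (no result reported), so nothing can be said of it in numbers.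

Compound 3 `N/C(CC(O)c1cccc2ccccc12)=N\N=C\c1ccco1` has not yet been measured in this assay. Its structure differs from compound 1 in one place (furan-2-yl in place of 3,4-dichlorophenyl on a carbon with a double bond to nitrogen). For the measured compounds named here, no step between two measured compounds is available to calibrate this change, since the only other entry, compound 2, has no number.

Going by the values given here, with a single reference value and no measured step, the expectation rests on compound 1 alone at 16000 nM. The step from compound 1 to compound 3 is expected to be small, a 1.6-fold higher number from compound 1 to compound 3 (0.19 log units; within the scatter), leaning if at all toward a higher number, and within or just beyond the scatter. Compound 3 is thus estimated at 25000 nM, in the range from 9000 nM to 70000 nM.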

Compound 3, half-maximal inhibitory concentration: 145000 nM
Compound 3: the middle estimate sits 5.8-fold (0.76 log units) below what was measured, and the stated range ends below it.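

Among these compounds, the first measured step shows that the group on a carbon with a double bond to nitrogen is not a silent position in this assay: replacing 3,4-dichlorophenyl with furan-2-yl gives a 9.1-fold higher number from compound 1 to compound 3 (0.96 log units; beyond the scatter) and thus moves the read-out toward weaker inhibition. Among the compounds shown here, until now the series offered only one number and no measured change, whereas this single exchange, with the rest of the core of compound 1 left as it stands, carries a shift clearly beyond the usual scatter. Nothing measured here accounts for the size of this shift.

The compounds shown leave open whether the step follows from losing the two chlorine atoms or from exchanging the six-membered carbon ring for the five-membered ring with its oxygen, a separation that a plain phenyl or a thiophen-2-yl at this place would allow. Also open, from the compounds shown here alone, is whether the same exchange would read alike on the core of compound 2, whose entry carries no number.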